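The source may hold more compounds than are shown below. What is called first, only, known or untested is meant among the compounds shown, and "the series" means these compounds.

Measured so far in a functional assay on MOLT-4 cells (Homo sapiens) for antiproliferative activity; a higher number here means a weaker inhibitor, a lower number a stronger inhibitor:
- Compound 1 `COc1cc(C(=O)c2sc(-c3ccc(-c4ccccc4)cc3)cc2N)cc(OC)c1OC`: > 10000 nM
- Compound 2 `COc1cc(C(=O)c2sc(-c3ccc(Br)cc3)cc2N)cc(OC)c1OC`: 92 nM
- Compound 3 `COc1cc(C(=O)c2sc(-c3ccc([N+](=O)[O-])cc3)cc2N)cc(OC)c1OC`: 110 nM

The entry for compound 1 is a limit of the assay, not a number. Within the data shown here, compound 3 therefore has only one numerical neighbour, and the gap to it is small: a 1.2-fold higher number from compound 2 to compound 3 (0.08 log units; within the scatter). The two values cannot be separated in this assay.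

Compound 4 `COc1cc(C(=O)c2sc(-c3ccc(Cl)cc3)cc2N)cc(OC)c1OC` is still unmeasured. It is reached from compound 3 by placing chloro in place of nitro on an aromatic carbon.

The large steps, an at least 100-fold lower number from compound 1 to compound 2 (2.03 log units; beyond the scatter) and an at least 90-fold lower number from compound 1 to compound 3 (1.95 log units; beyond the scatter), both start from the phenyl group of compound 1, so they say little about this change. The closest guide is the exchange of bromo and nitro at the same place, which stayed within the scatter at a 1.2-fold higher number from compound 2 to compound 3 (0.08 log units; within the scatter). No step beyond the scatter is therefore expected, and the expected change is a 1.1-fold lower number from compound 3 to compound 4 (0.04 log units; within the scatter).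

Compound 4 is estimated at 100 nM, with an expected range from 40 nM to 250 nM.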

Compound 4, half-maximal inhibitory concentration: 77 nM
Beside the measured number, compound 4's estimate is 1.3-fold (0.11 log units) above it; the measured number falls inside the stated range.
By their numbers in this assay, from the lowest: compounds 4, 2 and 3 (each within the scatter of the next). At a limit, above all of these: compound 1.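

In this assay, the 4-nitrophenyl to 4-chlorophenyl exchange replaces a group of 3 heavy atoms and 2 hydrogen-bond acceptors with a single chlorine atom, yet the values stay within the scatter (a 1.4-fold lower number from compound 3 to compound 4 (0.15 log units; within the scatter)), and chloro likewise cannot be separated from bromo at this place (a 1.2-fold lower number from compound 2 to compound 4 (0.08 log units; within the scatter)). Phenyl is the only group shown here that stands apart from chloro, by a large step (an at least 120-fold lower number from compound 1 to compound 4 (2.11 log units; beyond the scatter)), as it does from bromo and nitro. The entry for compound 1 is a limit, not a number: the limit of > 10000 nM in this assay, at which 1 of the 4 values shown sits.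

On these data alone, it remains open whether an amine, a carboxylic acid or a longer chain at this place would stay with compound 2, compound 3 and compound 4 or move towards compound 1. The compounds shown also leave open whether a group smaller than chloro, such as fluoro, would keep the same level.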